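The source may report more compounds than this note shows. Statements on the series, on what has been measured and on what is new or still open speak of the compounds shown alone.

Compound 1, `COc1cc[nH]c1/C=C1\C(=O)Nc2ccc(F)c(C#C[C@@H](C)O)c21`, gives 130 nM in a functional assay on SW480 cells (Homo sapiens) for inhibition; a higher number here means a weaker inhibitor, a lower number a stronger inhibitor. Compound 2, `COc1cc[nH]c1/C=C1\C(=O)Nc2ccc(F)c(C#C[C@H](C)O)c21`, gives 400 nM in this assay. Compound 3, `COc1cc[nH]c1/C=C1\C(=O)Nc2ccc(F)c(C#C[C@@H](N)[C@@H](C)O)c21`, gives 210 nM in this assay.

Compound 3 holds the second highest of the three numbers in this assay. Its nearest neighbour is compound 1, reached by a 1.6-fold higher number from compound 1 to compound 3 (0.21 log units; within the scatter); its furthest is compound 2, reached by a 1.9-fold lower number from compound 2 to compound 3 (0.28 log units; within the scatter). Going by the values given here, the only step that goes beyond the scatter is a 3.1-fold higher number from compound 1 to compound 2 (0.49 log units; beyond the scatter), and it rests on (the fact that compounds 1 and 2 differ only in the configuration as drawn).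

Compound 4, `COc1cc[nH]c1/C=C1\C(=O)Nc2ccc(F)c(C#CC3(O)CCOCC3)c21`, is not yet measured. It differs from compound 3 by 4-hydroxyoxan-4-yl in place of 1-amino-2-hydroxypropyl on a triple-bonded carbon. The measured steps at this position, from compound 1 and from compound 2 to compound 3, each exchange the chain on the triple-bonded carbon and each stay within the scatter. Among the compounds with values here, the change to compound 4 sits at the same place, removes both stereocentres and brings in a ring, so no measured step covers it closely. On what is shown, no step beyond the scatter is expected in either direction in this assay, and the estimated step is a 1.0-fold higher number from compound 3 to compound 4 (0.02 log units; within the scatter).

Compound 4 is therefore estimated at 220 nM in this assay, within a range from 70 nM to 700 nM.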

Compound 4, half-maximal inhibitory concentration: 290 nM
The estimate for compound 4 lay 1.3-fold (0.12 log units) below the measured number; low and high end bracket the measured number.
By their numbers in this assay, from the lowest: compounds 1, 3, 4 and 2 (each within the scatter of the next, the first and the last beyond it).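

Going by these compounds alone, the triple-bonded carbon accepts a ring as well as an open chain: the 4-hydroxyoxan-4-yl group, with its six-membered non-aromatic ring and no defined stereocentre, stays close to two of the earlier compounds in this assay, with a 1.4-fold higher number from compound 3 to compound 4 (0.14 log units; within the scatter) and a 1.4-fold lower number from compound 2 to compound 4 (0.14 log units; within the scatter). What is new is that a change of group at this place now passes the scatter, though against one partner only, with a 2.2-fold higher number from compound 1 to compound 4 (0.35 log units; beyond the scatter), whereas both earlier exchanges stayed inside it. Compound 4 thus lies within the scatter of one 1-hydroxyethyl compound and beyond it of the other, and the gap between those two, a 3.1-fold higher number from compound 1 to compound 2 (0.49 log units; beyond the scatter), rests on a single feature: the fact that compounds 1 and 2 differ only in the configuration as drawn.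

The compounds shown leave open what the ring oxygen and the hydroxyl of the 4-hydroxyoxan-4-yl group each contribute, and a 1-hydroxycyclohexyl group or an unsubstituted oxan-4-yl group would speak to that. Also open, on these data alone, is what the amine of the 1-amino-2-hydroxypropyl chain adds by itself, which a simple aminoethyl chain on the same carbon would help to separate from the hydroxyl.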